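From methyl to tert-butoxycarbonyl on an aromatic nitrogen

A few compounds are considered here, and "the series" means these few. Any claim that something is new, unique, unknown or untested is made for them only; others in the source may bear on it.

Three compounds with one shared core have numbers in a functional assay on B16-F0 cells (Mus musculus) for inhibition, read by CCK-8 assay, with a stated time of 48 h (a lower number here means a stronger inhibitor, a higher number a weaker inhibitor), so far. Compound 2 `COc1cc(-c2ccnc3cc(-c4c[nH]c5ccccc45)nn23)cc(OC)c1OC` has hydrogen on the aromatic nitrogen and gives 40 nM in this test. Compound 1 `COc1cc(-c2ccnc3cc(-c4cn(CO)c5ccccc45)nn23)cc(OC)c1OC` has hydroxymethyl there and gives 93 nM in the same test. Compound 3 `COc1cc(-c2ccnc3cc(-c4cn(C)c5ccccc45)nn23)cc(OC)c1OC` has methyl there and gives 185 nM as its value. Two steps fix where that value stands: a 4.6-fold higher number from compound 2 to compound 3 (0.67 log units; beyond the scatter) is beyond the scatter, whereas a 2.0-fold higher number from compound 1 to compound 3 (0.30 log units; within the scatter) is within it.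

Among the measured compounds shown here, in compound 4 `COc1cc(-c2ccnc3cc(-c4cn(C(=O)OC(C)(C)C)c5ccccc45)nn23)cc(OC)c1OC` the core stays the same, and tert-butoxycarbonyl stands in place of methyl on an aromatic nitrogen tert-butoxycarbonyl in place of methyl on an aromatic nitrogen as the only change. For the measured compounds named here, no measured compound carries a group of this kind, so the guidance is indirect. Both measured replacements of hydrogen on that nitrogen raise the number, as a 2.3-fold lower number from compound 1 to compound 2 (0.37 log units; beyond the scatter) read in reverse and a 4.6-fold higher number from compound 2 to compound 3 (0.67 log units; beyond the scatter) show. A small further rise in this assay is therefore expected, of a size that may not clear the scatter. The expected move is a 1.6-fold higher number from compound 3 to compound 4 (0.21 log units; within the scatter) on this estimate. The estimated value for compound 4 is 300 nM and the expected range runs from 90 nM up to 1000 nM in all.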

Compound 4, half-maximal inhibitory concentration: 3070 nM
Compound 4: the middle estimate sits 10-fold (1.01 log units) below what was measured; measured number outside the range, above it.
By their numbers in this assay, from the lowest: compound 2; then compounds 1 and 3 (each within the scatter of the next); then compound 4.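

Tert-butoxycarbonyl on the aromatic nitrogen sets compound 4 clearly apart from the other three compounds in this assay, with a 17-fold higher number from compound 3 to compound 4 (1.22 log units; beyond the scatter), a 33-fold higher number from compound 1 to compound 4 (1.52 log units; beyond the scatter) and a 77-fold higher number from compound 2 to compound 4 (1.89 log units; beyond the scatter). Among the earlier compounds, the widest step was a 4.6-fold higher number from compound 2 to compound 3 (0.67 log units; beyond the scatter), so this position had shown only a modest spread across hydrogen, hydroxymethyl and methyl, and compound 4 now shows that a replacement here can cost far more, making it the weakest inhibitor of the four. The change from methyl, with 1 heavy atom and no hydrogen-bond acceptors, to tert-butoxycarbonyl, with 7 heavy atoms and 2 hydrogen-bond acceptors, is large, but no measurement at hand accounts for the loss.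

The compounds shown cannot separate the contribution of the bulky tert-butyl part from that of the carbonyl attached to the nitrogen. From the compounds shown here alone, an acetyl group, which keeps a carbonyl on the nitrogen with a smaller chain, and a plain butyl chain, which has no carbonyl, would each test one of these features, and how either would behave in this assay remains open.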